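This account rests on a few compounds, and the source may have more. Where it says the series, first, only, none or still open, it means among the compounds named here.

In an ADME assay on H1-HeLa cells (Homo sapiens) for cytotoxicity, read by MTT assay, with a stated time of 3 days (on this read-out lower numbers stand for higher toxicity in this test and higher numbers for lower toxicity in this test), three compounds have been measured so far. Compound 1 `CNC(=O)c1cc(Oc2ccc3cc(C(=O)OC(C)C)sc3c2)ccn1` gives 45700 nM, and compound 2 `CNC(=O)c1cc(Oc2ccc3c(C)c(C(=O)OCc4ccccc4)sc3c2)ccn1` gives 18800 nM.

Compound 3 `CCOC(=O)c1cc2ccc(Oc3ccccc3)cc2s1` reports > 100000 nM, which is a limit of the assay and not a number. Its true position on the scale is therefore unknown, and any comparison with it is loose.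

Compound 4 `CCOC(=O)c1sc2cc(Oc3ccccc3)ccc2c1C` differs from compound 3 in one place only: methyl in place of hydrogen on an aromatic carbon. In words, this is a methyl in place of hydrogen on an aromatic carbon, a small change to the shared core.

Among the compounds with values here, no pair of measured compounds shows the effect of this change alone. Compound 2 carries a methyl in that place and gives 18800 nM, while compound 1 carries a hydrogen there and gives 45700 nM, but these two compounds also differ in their esters, so their values offer only a weak hint.

A small step toward lower numbers in this assay is expected an at least 1.3-fold lower number from compound 3 to compound 4 (0.12 log units; that floor lies within the scatter), and it may turn out to be no real change at all. The assay may well report only a limit again. For compound 4 the estimated value is 75000 nM, with an expected range from 30000 nM to 100000 nM.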

Compound 4, half-maximal cytotoxic concentration: > 100000 nM
Compound 4 gave a limit, no number; the forecaster's own chance of this, stated with the estimate: 45%; at least 1.3-fold (0.12 log units) between middle value and limit.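

Within the data shown here, no step from compound 3 to compound 4 can be read in this assay, because both compounds give a limit of the assay and not a number: the limit of > 100000 nM in this assay, at which 2 of the 4 values shown sit.

The compounds shown leave open what a methyl in place of hydrogen on an aromatic carbon does on its own to this read-out.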